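A few compounds are considered here, and "the series" means these few. Any claim that something is new, unique, unknown or untested is made for them only; others in the source may bear on it.

Working notes on the series. In a functional assay on cells (Panel ovarian (Carcinoma cell lines), Homo sapiens) for inhibition, read by sulforhodamine B assay, with a stated time of 48 h (on this read-out lower numbers stand for higher toxicity in this test and higher numbers for lower toxicity in this test), compound 3 `CN1CCN(CCCOc2cccc3nc(Nc4ccc(F)c(F)c4)ccc23)CC1` gives 20500 nM. The other two measured members sit close: in this assay compound 2 `CN1CCN(CCCOc2cccc3nc(Nc4ccc(Cl)c(F)c4)ccc23)CC1` gives 11300 nM and compound 1 `CN1CCN(CCCOc2cccc3nc(Nc4ccc(Cl)c(C(F)(F)F)c4)ccc23)CC1` gives 10300 nM, so compound 3 holds the largest of three numbers that all lie within the scatter of one another, as a 1.8-fold higher number from compound 2 to compound 3 (0.26 log units; within the scatter) and a 2.0-fold higher number from compound 1 to compound 3 (0.30 log units; within the scatter) show.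

The next step goes to compound 4 `CN1CCN(CCCOc2cccc3nc(Nc4cc(Cl)cc(Cl)c4)ccc23)CC1`: 3,5-dichlorophenyl in place of 3,4-difluorophenyl on a nitrogen on an aromatic ring. Every halogen swap on this phenyl so far, a 1.1-fold higher number from compound 1 to compound 2 (0.04 log units; within the scatter) as much as a 1.8-fold higher number from compound 2 to compound 3 (0.26 log units; within the scatter), stayed within the scatter, so no step beyond the scatter is expected in this assay, at most a drift of a 1.5-fold lower number from compound 3 to compound 4 (0.17 log units; within the scatter). Compound 4 is therefore estimated at 14000 nM, within 5500 nM to 35000 nM.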

Compound 4, concentration lethal to 50% of the cells: 9180 nM
Compound 4: the middle estimate sits 1.5-fold (0.18 log units) above what was measured; the measured number falls inside the stated range.
By their numbers in this assay, from the lowest: compounds 4, 1, 2 and 3 (each within the scatter of the next, the first and the last beyond it).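

In this assay, within the data shown here, a 2.2-fold lower number from compound 3 to compound 4 (0.35 log units; beyond the scatter) is the first step beyond the scatter, though a modest one, and in it the halogen changes in both kind and place on the phenyl. The other two steps, a 1.2-fold lower number from compound 2 to compound 4 (0.09 log units; within the scatter) and a 1.1-fold lower number from compound 1 to compound 4 (0.05 log units; within the scatter), stay within the scatter, so compound 4 separates from compound 3 only. Nothing available explains this step.

The compounds shown leave open whether the step follows the kind of halogen or its place, which 3,5-difluorophenyl would address. On these data alone, how a phenyl carrying a carboxylic acid or an amine would read also remains open.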